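Replacing a benzyloxy group with a carboxy group

The compounds below may be only part of what the source reports. "The series", "measured", "known", "first", "only" and "open" are said of these compounds alone.

Measured compounds:
- compound 1, `CCc1ccc(C(=O)/C=C/c2ccc3c(c2)B(O)OC3)cc1`: 20600 nM
- compound 2, `O=C(/C=C/c1ccc2c(c1)B(O)OC2)c1ccc(OCc2ccccc2)cc1`: > 100000 nM

Compound 1 was tested in a toxicity assay on WI-38 cells (Homo sapiens) for cytotoxicity, read by MTT assay, with a stated time of 48 h (on this read-out higher numbers stand for weaker inhibition and lower numbers for stronger inhibition), and gave 20600 nM. For compound 2 the result is only a limit of the method, > 100000 nM, so its true value is not pinned to a number. The change from compound 1 to compound 2 is a benzyloxy in place of ethyl on an aromatic carbon, and it gave an at least 4.8-fold higher number from compound 1 to compound 2 (0.68 log units; beyond the scatter); the size cannot be stated more closely because of the limit of > 100000 nM in this assay, at which 1 of the 2 values shown sits.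

Compound 3, `O=C(O)c1ccc(C(=O)/C=C/c2ccc3c(c2)B(O)OC3)cc1`, differs from compound 2 by carboxy in place of benzyloxy on an aromatic carbon. Among the measured compounds shown here, no measured step covers this particular exchange; the only one available concerns the entry of the benzyloxy group, which weakened inhibition. With compound 2 known only as a limit, the direction of an at least 1.2-fold lower number from compound 2 to compound 3 (0.09 log units; that floor lies within the scatter) is estimated with little confidence. Compound 3 is expected at 80000 nM, within 20000 nM to 250000 nM.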

Compound 3, half-maximal inhibitory concentration: > 100000 nM
Compound 3: no number, only a limit (the forecaster's own chance of this, stated with the estimate: 45%); at least 1.2-fold (0.09 log units) between middle value and limit.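

In this assay, putting carboxy in place of ethyl at this position, on an aromatic carbon para to a large group, gives an at least 4.8-fold higher number from compound 1 to compound 3 (0.68 log units; beyond the scatter). Benzyloxy brought a ring with it and carboxy has none, so among these compounds a ring in the entering group is not needed for this weaker inhibition, and compound 1, with its ethyl group, remains the only one of the three with a measured number. The step between compound 2 and compound 3 cannot be read, and neither compound can be ranked against the other, because both results are limits: the limit of > 100000 nM in this assay, at which 2 of the 3 values shown sit.

Going by these compounds, what stays open is whether ethyl itself is special at this position or whether other small groups would serve as well. A propyl chain or an amine here would begin to separate these two possibilities.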